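Oral exposure of the pyrazinyl ether analogue of compound 3

A few compounds are considered here, and "the series" means these few. Any claim that something is new, unique, unknown or untested is made for them only; others in the source may bear on it.

Working notes on the series. Compound 3 `C[C@@H](Cn1c(=O)[nH]/c(=N\c2ccc(Oc3ccccn3)cc2)n(Cc2ccc(Cl)cc2)c1=O)C(=O)O` is the point of departure. In an ADME assay on the whole organism (Rattus norvegicus) for pharmacokinetics, using cassette dosing, at a dose of 1 mg/kg by the oral route (a higher number here means that a larger share of the oral dose reaches the circulation, a lower number that a smaller share of the oral dose reaches the circulation), compound 3 gives 52.8%, the lowest of the three numbers in hand. Compound 1 `Cc1ccc(Cn2c(=O)n(C[C@H](C)C(=O)O)c(=O)[nH]/c2=N\c2ccc(OC(C)C)c(Cl)c2)cc1` gives in this assay a value of 73.1%, the nearest of the other numbers, and compound 2 `CC(C)Oc1ccc(/N=c2\[nH]c(=O)n(C[C@@H](C)C(=O)O)c(=O)n2Cc2ccc(Cl)cc2)cc1Cl` gives in this assay a value of 108%, the furthest; both stand beyond the scatter above compound 3. Going by the values given here, compounds 1 and 2 each differ from compound 3 in more than one place, so neither pair isolates a single change, and no step between measured compounds can be stated.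

Compound 4 `C[C@@H](Cn1c(=O)[nH]/c(=N\c2ccc(Oc3cnccn3)cc2)n(Cc2ccc(Cl)cc2)c1=O)C(=O)O` has not yet been measured. Its difference from compound 3: pyrazin-2-yl in place of pyridin-2-yl on an oxygen on an aromatic ring. Among the compounds with values here, no measured pair in this set isolates a ring exchange of this kind, so the expectation rests on the size of exchange alone. The step of a number 7.8 percentage points lower from compound 3 to compound 4 (within the scatter) is expected to be small, likely within the scatter, with no firm direction and a slight lean downward. Compound 4 is estimated at 45%, with a range from 20% to 75%.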

Compound 4, oral bioavailability: 56.5%
Estimate against measurement, compound 4: 11.5 percentage points below; the measured number falls inside the stated range.
By their numbers in this assay, from the lowest: compounds 3 and 4 (each within the scatter of the next); then compound 1; then compound 2.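

The pair of compound 3 and compound 4 is the only one here that differs in one place: in this assay, pyrazin-2-yl in place of pyridin-2-yl on an oxygen on an aromatic ring gives a number 3.7 percentage points higher from compound 3 to compound 4 (within the scatter), so the two compounds cannot be told apart. At this position, then, the further ring nitrogen and hydrogen-bond acceptor counted in pyrazin-2-yl come with no readable difference in oral bioavailability for this pair. Nothing at hand bears on the reason for this result.

The steps from compound 4 to compound 1 and to compound 2 cannot be read, as each of those compounds differs from it in more than one place. Still open, going by these compounds, is whether a pyrimidin-2-yl ring, or a pyridin-2-yl ring carrying an amine, on the same oxygen would also stay within the scatter of compound 3.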